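A few compounds are considered here, and "the series" means these few. Any claim that something is new, unique, unknown or untested is made for them only; others in the source may bear on it.

Compound 1 `Cc1nn(CC(C)(C)O)cc1Nc1nc(N)c2c(C#N)c(N3CCC[C@H]3C)n(C)c2n1` has the lowest number of the three measured compounds: in an assay on isolated protein for inhibition of Leucine-rich repeat serine/threonine-protein kinase 2 (Homo sapiens), read by TR-FRET and LanthaScreen, with stated times of 50 min and 30 min, in the presence of a further agent that is not named here (on this read-out lower numbers stand for stronger inhibition and higher numbers for weaker inhibition), compound 1 gives 49 nM. Compound 2 `Cn1c(-c2ccccc2)c(C#N)c2c(N)ncnc21`, a smaller compound that shares the core, sits well higher; compound 2 gives 1260 nM. Compound 3 `Cn1c(N)c(C#N)c2c(N)ncnc21`, which carries an amino group where compound 2 carries a phenyl, sits higher still; compound 3 gives 14400 nM. Among the measured compounds shown here, the only single-point change among the measured compounds is an 11-fold higher number from compound 2 to compound 3 (1.06 log units; beyond the scatter).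

The unmeasured compound 4 `Cc1n[nH]cc1Nc1nc(N)c2c(C#N)c(N3CCC[C@H]3C)n(C)c2n1` differs from compound 1 in one place: hydrogen in place of 2-hydroxy-2-methylpropyl on an aromatic nitrogen. For the measured compounds named here, the one measured step concerns a different kind of change at a different place, an amino in place of phenyl on an aromatic carbon, so it says little about removing a 2-hydroxy-2-methylpropyl group from an aromatic nitrogen. Going by the values given here, since nothing among the measured compounds tests this change, the expectation is for a modest loss, not a large one, so that compound 4 is expected to give a somewhat higher number than compound 1. The estimate for compound 4 is 110 nM in this assay, with a likely range from 30 nM to 400 nM. This estimate corresponds to an expected step of a 2.2-fold higher number from compound 1 to compound 4 (0.35 log units; beyond the scatter).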

Compound 4, half-maximal inhibitory concentration: 42 nM
Beside the measured number, compound 4's estimate is 2.6-fold (0.42 log units) above it; low and high end bracket the measured number.
By their numbers in this assay, from the lowest: compounds 4 and 1 (each within the scatter of the next); then compound 2; then compound 3.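

In this assay, replacing the 2-hydroxy-2-methylpropyl group on the aromatic nitrogen with a hydrogen gives a 1.2-fold lower number from compound 1 to compound 4 (0.07 log units; within the scatter), so compound 1 and compound 4 cannot be told apart on this read-out. Among the compounds shown here, this is the first measured change at this position, and it shows that the chain, with its 5 heavy atoms and its hydroxyl group, is not needed to reach a number of this size: the bare nitrogen bearing only a hydrogen does just as well in this assay. No measurement shown here accounts for why the two compounds read alike.

As far as these compounds go, with only a hydrogen and one branched chain to compare, it remains open whether this position accepts any group or only these two, since a chain ending in an amine or a carboxylic acid, or a cyclopropyl ring, could give a very different number. From the compounds shown here alone, it also remains open whether compound 1 and compound 4 stay alike in tests other than this one on isolated protein.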